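The source may report more compounds than this note shows. Statements on the series, on what has been measured and on what is new or still open speak of the compounds shown alone.

Measured compounds in an assay on a protein complex for inhibition of NEDD8 activating enzyme (Homo sapiens), read by HTRF, with a stated time of 2 h, in the presence of a further agent that is not named here; a higher number here means a weaker inhibitor, a lower number a stronger inhibitor:
compound 1 `NS(=O)(=O)OC[C@@H]1C[C@@H](n2nnc3c(NCc4ccco4)ncnc32)C[C@@H]1O` gives 30.6 nM
compound 2 `NS(=O)(=O)OC[C@@H]1C[C@@H](n2nnc3c(NCc4cccs4)ncnc32)C[C@@H]1O` gives 15.9 nM
compound 3 `NS(=O)(=O)OC[C@@H]1C[C@@H](n2nnc3c(NC4CCCC4)ncnc32)C[C@@H]1O` gives > 10000 nM

Compound 3 stands apart: its result in this assay is only (the limit of > 10000 nM in this assay, at which 1 of the 3 values shown sits), so no number is known for it. Compound 4 `COC(=O)[C@H]1C=C[C@@H](Nc2ncnc3c2nnn3[C@@H]2C[C@@H](COS(N)(=O)=O)[C@@H](O)C2)C1` differs from compound 3 by a group of 9 heavy atoms (7 carbon, 2 oxygen; one five-membered non-aromatic ring of carbon only) in place of a group of 5 heavy atoms (5 carbon; one five-membered non-aromatic ring of carbon only), on a nitrogen on an aromatic ring. For the measured compounds named here, two measured steps touch this position: an at least 320-fold higher number from compound 1 to compound 3 (2.51 log units; beyond the scatter) and an at least 620-fold higher number from compound 2 to compound 3 (2.79 log units; beyond the scatter), both large. Both show that a carbocycle directly on this nitrogen, in place of an arylmethyl group, loses strongly. Compound 4 keeps a carbocycle on that nitrogen; the added ester and double bond have no measured parallel. Compound 4 is therefore expected to remain weak, with an at least 1.2-fold lower number from compound 3 to compound 4 (0.09 log units; that floor lies within the scatter), and an estimated 8000 nM (range 1500 nM to 50000 nM).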

Compound 4, half-maximal inhibitory concentration: 80.9 nM
Beside the measured number, compound 4's estimate is 99-fold (2.00 log units) above it; measured number outside the range, below it.
By their numbers in this assay, from the lowest: compounds 2 and 1 (each within the scatter of the next); then compound 4. At a limit, above all of these: compound 3.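

The result shows that a carbocycle directly on this nitrogen need not lose strongly in this assay: replacing cyclopentyl with the ring of compound 4, which carries an ester and a ring double bond, gives an at least 120-fold lower number from compound 3 to compound 4 (2.09 log units; beyond the scatter). That step starts from a limit of the assay, not a number: the limit of > 10000 nM in this assay, at which 1 of the 4 values shown sits. Compound 4 still falls short of the (thiophen-2-yl)methyl and (furan-2-yl)methyl groups, with a 5.1-fold higher number from compound 2 to compound 4 (0.71 log units; beyond the scatter) and a 2.6-fold higher number from compound 1 to compound 4 (0.42 log units; beyond the scatter).

The compounds shown do not separate the part played by the ester from that of the double bond. Going by these compounds, whether a carboxylic acid or an amide in place of the ester would hold this level also remains open.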